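Swapping the ring on a urea: from pyrazine to pyridine

The compounds below may be only part of what the source reports. "The series", "measured", "known", "first", "only" and "open" are said of these compounds alone.

Measured compounds:
compound 1, `N#Cc1ccc(NC(=O)Nc2ccc(F)c(C(F)(F)F)c2)cc1`, 12 uL/min
compound 2, `NC(=O)c1ccccc1NC(=O)Nc1ccc(F)c(C(F)(F)F)c1`, 69 uL/min
compound 3, `O=C(Nc1ccc(F)c(C(F)(F)F)c1)Nc1cnccn1`, 160 uL/min

These three ureas share one half of the molecule and differ in the ring on the other nitrogen. In an ADME assay on microsomes from liver (Mus musculus) for metabolic stability, using NADPH, with a stated time of 60 min (a higher number here means faster removal of the compound, a lower number slower removal), compound 3 gives the highest of the three numbers. Its nearest neighbour is compound 2, whose value is lower by a step beyond the scatter, and the furthest is compound 1, whose value lies far lower still. Compound 3 is therefore the fastest cleared of the set as measured here.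

Compound 4, `O=C(Nc1cccnc1)Nc1ccc(F)c(C(F)(F)F)c1`, is a close relative of compound 3: pyridin-3-yl in place of pyrazin-2-yl on an amide-type nitrogen. Going by the values given here, no measured pair in this set shows what that particular swap does, so no step between measured compounds can guide the estimate; only the three values themselves are available.

The expectation is a step from compound 3 to compound 4 of about a 1.2-fold lower number from compound 3 to compound 4 (0.09 log units; within the scatter), that is, no change beyond the scatter. Compound 4 is thus estimated at 130 uL/min, with a range from 60 uL/min to 280 uL/min.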

Compound 4, intrinsic clearance in a liver preparation (reported as CLH), per the amount of preparation that the assay uses in the Mus musculus assay: 154 uL/min
Compound 4: middle estimate off by 1.2-fold (0.07 log units), on the low side; the range from low to high includes it.
By their numbers in the Mus musculus assay, from the lowest: compound 1; then compound 2; then compounds 4 and 3 (each within the scatter of the next).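

Pyridin-3-yl in place of pyrazin-2-yl on an amide-type nitrogen is the first single change in this set, and in the Mus musculus assay it makes no difference beyond the scatter (a 1.0-fold lower number from compound 3 to compound 4 (0.02 log units; within the scatter)). In a physicochemical assay for solubility, read by nephelometry, measured as kinetic solubility, at pH 2 (a lower number here means a less soluble compound, a higher number a more soluble compound), compound 3 gives 1.6 ug/mL and compound 4 gives 50 ug/mL so the same swap that leaves the number in the Mus musculus assay in place moves the number in the physicochemical assay a long way. At this position, then, the ring swap alters solubility without altering removal by the liver preparation: the measured solubility of compound 3, 1.6 ug/mL, and of compound 4, 50 ug/mL, a 31-fold higher number (1.49 log units; beyond the scatter).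

This single pair cannot show whether the swap behaves the same way on a different urea partner. It also leaves open what an amine or a carboxylic acid on the pyridin-3-yl ring would do to either number.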